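The source may hold more compounds than are shown below. What is called first, only, known or untested is meant among the compounds shown, and "the series" means these compounds.

Measured compounds in a functional assay on KB3 cells (Homo sapiens) for antiproliferative activity, read by MTT assay, with a stated time of 96 h; a lower number here means a stronger inhibitor, a higher number a weaker inhibitor:

- compound 1, `C=C(C)[C@H]1CC(=O)C(C)=C2[C@@H](C(=O)OCC)O[C@@H](c3ccc(Cl)cc3Cl)[C@@H]21`: 3000 nM
- compound 2, `C=C(C)[C@H]1CC=C(C)[C@@]2(O)[C@@H]1[C@H](c1cccc(Cl)c1Cl)O[C@@H]2C(=O)OCC`: 5000 nM
- compound 3, `C=C(C)[C@H]1CC=C(C)C2=CO[C@@H](c3cccc4ccccc34)[C@@H]21`: > 100000 nM, which is a limit of this assay and not a number

Compound 1 has the lowest of the two numbers shown in this assay. Its nearest neighbour is compound 2, whose number is higher, but the gap between the two lies within the scatter of repeated measurements, so no order between compound 1 and compound 2 can be read from these data. Compound 3 sits at the limit (the limit of > 100000 nM in this assay, at which 1 of the 3 values shown sits).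

The unmeasured compound 4, `C=C(C)[C@H]1CC(=O)C(C)=C2[C@@H](C(=O)OCC)O[C@@H](c3ccccc3Br)[C@@H]21`, shares the core of compound 1 and differs from it in one place: 2-bromophenyl in place of 2,4-dichlorophenyl on a saturated ring carbon. The change removes one chlorine from the aromatic ring and replaces the remaining chlorine with bromine, keeping the ring itself and its lack of donors and acceptors. Among the compounds with values here, no measured pair isolates this exchange, so its effect has to be taken as unknown in sign. Given that the two halogenated aryl variants measured so far, compound 1 and compound 2, fall within the scatter of each other, the step of a 1.3-fold higher number from compound 1 to compound 4 (0.12 log units; within the scatter) is expected to be small, most likely not beyond the scatter, with a slight lean toward a higher number.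

Compound 4 is therefore estimated at 4000 nM in this assay, with a range from 1500 nM to 12000 nM.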

Compound 4, half-maximal inhibitory concentration: 70000 nM
Compound 4: middle estimate off by 18-fold (1.24 log units), on the low side, and the stated range ends below it.
By their numbers in this assay, from the lowest: compounds 1 and 2 (each within the scatter of the next); then compound 4. At a limit, above all of these: compound 3.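

In this assay, the aryl group on the saturated ring carbon next to the ring oxygen proves to be a sensitive place in the core of compound 1: 2-bromophenyl in place of 2,4-dichlorophenyl gives a 23-fold higher number from compound 1 to compound 4 (1.37 log units; beyond the scatter). Within the data shown here, this is the first pair that differs in one place, so it is the first direct reading of this position, and it shows that a change confined to the halogens on the aromatic ring can carry a large step while the rest of the molecule stays the same. No measurement shown here gives a cause for this step.

The exchange removes one chlorine and replaces the other with bromine in a single move, which leaves open which of the two changes carries the step; a 2-chlorophenyl or a 4-chlorophenyl group at this place would separate them. Also open, going by these compounds, is how the position responds to a substituent other than a halogen, such as a methoxy group or an amine on the aromatic ring.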